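Trimethoxyphenyl Benzimidazoles: Swapping the Pendant Aryl Ring

The source may hold more compounds than are shown below. What is called first, only, known or untested is meant among the compounds shown, and "the series" means these compounds.

Measured so far:
compound 1 `COc1cccc(-c2ccc3ncn(-c4cc(OC)c(OC)c(OC)c4)c3c2)c1`: 3310 nM
compound 2 `COc1cc(-n2cnc3ccc(-c4ccccc4Cl)cc32)cc(OC)c1OC`: > 10000 nM
compound 3 `COc1cc(-n2cnc3ccc(-c4ccc(C)cc4)cc32)cc(OC)c1OC`: 200 nM

In a functional assay on SGC-7901 cells (Homo sapiens) for antiproliferative activity, read by MTT assay, with a stated time of 72 h (a lower number here means a stronger inhibitor, a higher number a weaker inhibitor), compound 1 gives 3310 nM, the highest of the two numbers shown. Compound 3 sits well below it, with a 17-fold lower number from compound 1 to compound 3 (1.22 log units; beyond the scatter). Compound 2 reaches only the assay limit (the limit of > 10000 nM in this assay, at which 1 of the 3 values shown sits), so its value is a limit rather than a number, and an at least 3.0-fold higher number from compound 1 to compound 2 (0.48 log units; beyond the scatter).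

The next step keeps the shared core of compound 1 and changes only the pendant aryl ring: 3-hydroxy-4-methoxyphenyl in place of 3-methoxyphenyl on an aromatic carbon. This gives compound 4 `COc1ccc(-c2ccc3ncn(-c4cc(OC)c(OC)c(OC)c4)c3c2)cc1O`.

The measured steps bear on this change only loosely. Compound 3 shows that a 4-methylphenyl in place of 3-methoxyphenyl lowers the number by a large margin, while compound 2 shows that 2-chlorophenyl pushes it past the limit. The 3-hydroxy-4-methoxyphenyl entering in compound 4 keeps substitution at the position numbered 3 in its name, as in compound 1, and adds a group at the position numbered 4, as in compound 3. A step toward lower numbers, smaller than that of compound 3, is therefore expected: a 4.7-fold lower number from compound 1 to compound 4 (0.67 log units; beyond the scatter). For compound 4 the expected value in this assay is 700 nM, with a range from 150 nM to 3500 nM.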

Compound 4, half-maximal inhibitory concentration: 44 nM
Estimate against measurement, compound 4: 16-fold (1.20 log units) above; the measured number lies below the stated range.
By their numbers in this assay, from the lowest: compound 4; then compound 3; then compound 1. At a limit, above all of these: compound 2.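

In this assay, the pendant aryl ring at this position accepts two substituents and gains from them, with a 75-fold lower number from compound 1 to compound 4 (1.88 log units; beyond the scatter), so the 3-methoxyphenyl of compound 1 sits far from the best this position allows. The 4-methylphenyl of compound 3 no longer marks the low end of the series, with a 4.5-fold lower number from compound 3 to compound 4 (0.66 log units; beyond the scatter), and compound 4 is now the strongest inhibitor of the four compounds shown. The distance from the 2-chlorophenyl ring is an at least 220-fold lower number from compound 2 to compound 4 (2.35 log units; beyond the scatter), a span that can only be given as a minimum, since compound 2 stands at a limit and not at a number: the limit of > 10000 nM in this assay, at which 1 of the 4 values shown sits.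

The 3-hydroxy-4-methoxyphenyl ring differs from the 3-methoxyphenyl ring in two ways at once, so the compounds shown do not say how much of the gain belongs to the hydroxy group and how much to the methoxy group at the position numbered 4. A 3-hydroxyphenyl or a 4-methoxyphenyl ring would divide the two, and an amino group in place of the hydroxy group would test whether oxygen is needed there in this assay.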